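Compound 3: ethynyl replaces benzofuranyl, little change expected

A few compounds are considered here, and "the series" means these few. Any claim that something is new, unique, unknown or untested is made for them only; others in the source may bear on it.

In a functional assay on HCT-116 cells (Homo sapiens), read by MTT assay, with a stated time of 72 h (a higher number here means a weaker inhibitor, a lower number a stronger inhibitor), compound 1 `COc1ncnc2c1c(-c1ccccc1)cn2[C@@H]1O[C@H](CO)[C@@H](O)[C@H]1O` gives only a limit, > 20000 nM. Among the compounds with values here, compound 2 `COc1ncnc2c1c(-c1cc3ccccc3o1)cn2[C@@H]1O[C@H](CO)[C@@H](O)[C@H]1O` gives 14500 nM, the only actual number so far. Compound 3 `C#Cc1cn([C@@H]2O[C@H](CO)[C@@H](O)[C@H]2O)c2ncnc(OC)c12` carries ethynyl in place of 1-benzofuran-2-yl on an aromatic carbon. Within the data shown here, the one measured step, an at least 1.3-fold lower number from compound 1 to compound 2 (0.13 log units; that floor lies within the scatter), offers little guidance: its floor lies within the scatter, and the limit of > 20000 nM in this assay, at which 1 of the 2 values shown sits, leaves its true size open. An estimated step of a 1.8-fold lower number from compound 2 to compound 3 (0.26 log units; within the scatter) is therefore expected in this assay, nothing beyond the scatter. For compound 3 the estimate is 8000 nM, with an expected range of 1500 nM to 20000 nM.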

Compound 3, half-maximal inhibitory concentration: 5140 nM
The estimate for compound 3 lay 1.6-fold (0.19 log units) above the measured number, within the range that was stated.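

Within the data shown here, at this position, on an aromatic carbon of the five-membered ring, ethynyl gives the first step beyond the scatter in this assay: a 2.8-fold lower number from compound 2 to compound 3 (0.45 log units; beyond the scatter). Against phenyl the step is an at least 3.8-fold lower number from compound 1 to compound 3 (0.59 log units; beyond the scatter), and its true size stays open, since it rests on a limit for compound 1: the limit of > 20000 nM in this assay, at which 1 of the 3 values shown sits. Among the three compounds, then, an aromatic ring at this position is not required for the lowest number.

On these data alone, whether a nitrile, an aminomethyl group or a longer alkyne at this position would go lower remains open. Also open, as far as these compounds go, is whether this order holds in other cell lines.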